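A few compounds are considered here, and "the series" means these few. Any claim that something is new, unique, unknown or untested is made for them only; others in the source may bear on it.

Compound 1 `O=[N+]([O-])c1ccc(C2=NOC(c3ccccc3)O2)s1` is characterised only by a limit in an ADME assay on Vero cells (Chlorocebus sabaeus) for cytotoxicity, read by sulforhodamine B assay, with a stated time of 72 h; a lower number here means a stronger inhibitor, a higher number a weaker inhibitor: in that assay compound 1 gives < 180000 nM, which is a limit of the assay rather than a measured number. Two close analogues are known. Compound 2 `O=[N+]([O-])c1ccc(C2=NOC(c3ccccc3O)O2)s1` carries a hydroxy in place of hydrogen on an aromatic carbon, and in this assay compound 2 gives < 180000 nM, again a limit. Compound 3 `COc1ccc(C2ON=C(c3ccc([N+](=O)[O-])s3)O2)cc1` carries a methoxy in place of hydrogen on an aromatic carbon, and in this assay compound 3 gives < 180000 nM, also a limit. Consequently a step that the two limits leave unreadable from compound 1 to compound 2 and a step that the two limits leave unreadable from compound 1 to compound 3 cannot be sized, since (the limit of < 180000 nM in this assay, at which 3 of the 3 values shown sit). Compound 4 `CC1(c2ccccc2)ON=C(c2ccc([N+](=O)[O-])s2)O1` differs from compound 1 by methyl in place of hydrogen on a saturated ring carbon. Within the data shown here, no measured step bears directly on such a change, and the two steps that exist are unreadable. Among the measured compounds shown here, the only guide is the limit of < 180000 nM in this assay, at which 3 of the 3 values shown sit. Compound 4 is therefore expected to give 100000 nM (range 30000 nM to 180000 nM) in this assay. The step this estimate implies, a step that the limit leaves unreadable from compound 1 to compound 4, is expected most likely to end in another limit.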

Compound 4, half-maximal inhibitory concentration: < 180000 nM
Compound 4 was reported as a limit (the forecaster's own chance of this, stated with the estimate: 85%); the middle value does not contradict the limit.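

In this assay compound 4 gives < 180000 nM, again a limit. Among these compounds, with compound 1 also held at a limit, no step between compound 1 and compound 4 can be read: the limit of < 180000 nM in this assay, at which 4 of the 4 values shown sit. The compounds shown leave open whether hydroxy, methoxy or methyl in place of hydrogen changes the half-maximal inhibitory concentration in this assay at all.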